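Swapping an Acyl Chain on the Amide

This account rests on a few compounds, and the source may have more. Where it says the series, first, only, none or still open, it means among the compounds named here.

Measured in a functional assay on KYSE-450 cells (Homo sapiens) for inhibition, read by MTT assay, with a stated time of 48 h; on this read-out higher numbers stand for weaker inhibition and lower numbers for stronger inhibition
Compound 1 `COc1cc(NCc2ccccc2)cc(OC)c1OC` gives > 80000 nM (a limit of the assay)
Compound 2 `COc1ccc(CN(C(C)=O)c2cc(OC)c(OC)c(OC)c2)cc1O` gives 160 nM
Compound 3 `CCC/C=C/C(=O)N(Cc1ccc(OC)c(O)c1)c1cc(OC)c(OC)c(OC)c1` gives 57 nM

Compound 3 has the lower of the two actual numbers in this assay, and compound 2 is its nearest neighbour. Compound 4 `COc1ccc(CN(C(=O)CCCCCl)c2cc(OC)c(OC)c(OC)c2)cc1O` carries 4-chlorobutyl in place of pent-1-en-1-yl on a carbonyl carbon. Among the compounds with values here, the one measured step at this place is modest: a 2.8-fold lower number from compound 2 to compound 3 (0.45 log units; beyond the scatter). That step replaced a much smaller group, whereas the two chains here match in heavy-atom count, so no step beyond the scatter is expected. The estimate means a 1.6-fold higher number from compound 3 to compound 4 (0.20 log units; within the scatter), an expected small rise. For compound 4 the estimated value is 90 nM, with an expected range of 25 nM to 350 nM.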

Compound 4, half-maximal inhibitory concentration: 770 nM
Compound 4: middle estimate off by 8.6-fold (0.93 log units), on the low side; measured number above the stated range.
By their numbers in this assay, from the lowest: compound 3; then compound 2; then compound 4. At a limit, above all of these: compound 1.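

At this place, on a carbonyl carbon whose other neighbours are an amide-type nitrogen, the heavy-atom count alone does not set the outcome: 4-chlorobutyl in place of pent-1-en-1-yl brings a 14-fold higher number from compound 3 to compound 4 (1.13 log units; beyond the scatter) with the count unchanged. Likewise, a 4.8-fold higher number from compound 2 to compound 4 (0.68 log units; beyond the scatter) for the added 3-chloropropyl runs opposite to the earlier step, so a longer chain does not by itself lower the number.

A plain pentyl chain would help separate the loss of the double bond from the entry of chlorine. The data shown offer no explanation for the rise.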